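This account rests on a few compounds, and the source may have more. Where it says the series, first, only, none or still open, it means among the compounds named here.

Measured compounds:
compound 1 `Cc1cccc(-n2cc(-c3ccccc3NS(=O)(=O)c3c[nH]c(=O)[nH]c3=O)nn2)c1` — 3150 nM
compound 2 `Cc1ccc(-n2cc(-c3ccccc3NS(=O)(=O)c3c[nH]c(=O)[nH]c3=O)nn2)cc1` — 2190 nM

In a functional assay on OVCAR-3 cells (Homo sapiens) for antiproliferative activity, read by MTT assay, with a stated time of 24 h (on this read-out lower numbers stand for stronger inhibition and higher numbers for weaker inhibition), compound 1 gives 3150 nM and compound 2 gives 2190 nM. Compound 2 sits at the low end of the two numbers, but the step of a 1.4-fold lower number from compound 1 to compound 2 (0.16 log units; within the scatter) lies within the scatter, so compound 1 is not separated from it; the two compounds are, on this evidence, equivalent.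

Compound 3 `O=c1[nH]cc(S(=O)(=O)Nc2ccccc2-c2cn(-c3ccc(F)cc3)nn2)c(=O)[nH]1` is the next member. Relative to compound 2 the change is fluoro in place of methyl on an aromatic carbon, read one bond further out as 4-methylphenyl to 4-fluorophenyl. For the measured compounds named here, no measured pair replaces methyl by fluoro on this ring. Going by the values given here, the only step in hand, from compound 1 to compound 2, moves the methyl around the same ring and was within the scatter; it bears on compound 3 only in showing that this ring tolerates small changes without a number beyond the scatter. No step beyond the scatter is therefore expected in this assay in either direction.

Compound 3 is expected at 2500 nM, with a range of 1200 nM to 5500 nM, meaning an expected step of a 1.1-fold higher number from compound 2 to compound 3 (0.06 log units; within the scatter).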

Compound 3, half-maximal inhibitory concentration: > 20000 nM
Compound 3: a limit, no number; the forecaster's own chance of this, stated with the estimate: 5%; middle value at least 8.0-fold (0.90 log units) from the limit.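

In this assay compound 3 gives > 20000 nM, which is a limit of the assay and not a number. Exchanging methyl for fluoro on this aromatic carbon, para to a large group, swaps one heavy atom for one heavy atom, yet the result is an at least 9.1-fold higher number from compound 2 to compound 3 (0.96 log units; beyond the scatter), and against the other methyl compound it is an at least 6.3-fold higher number from compound 1 to compound 3 (0.80 log units; beyond the scatter), whereas a 1.4-fold lower number from compound 1 to compound 2 (0.16 log units; within the scatter) left the two methyl compounds together. The ring on the aromatic nitrogen therefore does not accept every small change alike: what stands on it can matter more in this read-out than where the methyl sits, and the fluoro compound separates from both methyl compounds.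

The compounds shown do not tell whether the step follows from losing methyl or from bringing in fluoro; an unsubstituted phenyl, or chloro or methoxy on the same aromatic carbon, would separate these two readings. Also open is whether fluoro in the place of the methyl of compound 1 would give the same result, and nothing shown gives a cause for the step.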